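The source may hold more compounds than are shown below. What is called first, only, known or untested is meant among the compounds shown, and "the series" means these compounds.

Measured so far, in a functional assay on CCRF-CEM cells (Homo sapiens) for inhibition, read by sulforhodamine B assay, with a stated time of 48 h, tested at 10 uM; a higher number here means more inhibition at the concentration tested (going by the name of the read-out), a lower number less inhibition:
compound 1 `Fc1ccc(-c2cn3ccnc3c(-c3ccc4ncn(C5CCCCC5)c4c3)n2)cc1` gives 33.4%;
compound 2 `Clc1ccc(-c2cn3ccnc3c(-c3ccc4ncn(C5CCCCC5)c4c3)n2)cc1` gives 11.4%;
compound 3 `Fc1ccccc1-c1cn2ccnc2c(-c2ccc3ncn(C4CCCCC4)c3c2)n1` gives 22.5%.

Compound 1 stands highest of the three, with compound 3 nearest and compound 2 furthest, both gaps beyond the scatter. Compound 4 `FC(F)(F)c1cccc(-c2cn3ccnc3c(-c3ccc4ncn(C5CCCCC5)c4c3)n2)c1` has not yet been measured. It differs from compound 1 in one place: 3-(trifluoromethyl)phenyl in place of 4-fluorophenyl on an aromatic carbon. Going by the values given here, two measured steps bear on this, both starting from compound 1. Replacing fluoro with chloro gave a number 22 percentage points lower from compound 1 to compound 2 (beyond the scatter), and replacing 4-fluorophenyl with 2-fluorophenyl gave a number 10.9 percentage points lower from compound 1 to compound 3 (beyond the scatter). Every change away from 4-fluorophenyl seen so far lowered inhibition, so for compound 4 a drop beyond the scatter is expected, of about a number 18.4 percentage points lower from compound 1 to compound 4 (beyond the scatter). Compound 4 is therefore estimated at 15%, expected to fall between 2% and 30%.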

Compound 4, a percentage reported as inhibition, at one concentration (the size of the read-out at that concentration, not a potency): 27.3%
Estimate against measurement, compound 4: 12.3 percentage points below, within the range that was stated.
By their numbers in this assay, from the lowest: compound 2; then compounds 3, 4 and 1 (each within the scatter of the next, the first and the last beyond it).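

Replacing 4-fluorophenyl with 3-(trifluoromethyl)phenyl gives a number 6.1 percentage points lower from compound 1 to compound 4 (within the scatter), so this position can take a group with more heavy atoms without a change in inhibition beyond the scatter, and not every change away from 4-fluorophenyl lowers the number. The same group gives a number 4.8 percentage points higher from compound 3 to compound 4 (within the scatter) and a number 15.9 percentage points higher from compound 2 to compound 4 (beyond the scatter), which leaves compound 2 as the only one of the four set apart from compound 4. Nothing available explains these steps.

Still open, going by these compounds, is how a phenyl ring carrying an amine or a carboxylic acid would behave at this position. Also open, on these data alone, is whether a plain alkyl chain in place of the ring would keep inhibition.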